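A few compounds are considered here, and "the series" means these few. Any claim that something is new, unique, unknown or untested is made for them only; others in the source may bear on it.

Measured so far in a physicochemical assay for lipophilicity, in phosphate buffer, measured as octanol-water partition; a lower number here means a more polar compound, a higher number a more lipophilic compound:
compound 1, `Cc1nc2ccccc2c(=O)n1/N=C/c1ccc(Oc2ccc(Cl)cc2)cc1`, gives 4.6
compound 2, `Cc1ccc(Oc2ccc(/C=N/n3c(C)nc4ccccc4c3=O)cc2)cc1`, gives 4.32

Going by the values given here, compound 2 holds the lower of the two numbers, but its only neighbour, compound 1, is not separated from it beyond the scatter: the single measured step, a number 0.28 log units lower from compound 1 to compound 2 (within the scatter), is within the scatter. In structure that step exchanged a chloro for a methyl on an aromatic carbon.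

Compound 3, `Cc1nc2ccccc2c(=O)n1/N=C/c1ccc(Oc2ccccc2)cc1`, is the next compound, and it differs from compound 2 by hydrogen in place of methyl on an aromatic carbon. Among the compounds with values here, no measured pair covers the loss of a methyl for a hydrogen; the one step available, a number 0.28 log units lower from compound 1 to compound 2 (within the scatter), swaps one small group for another and so bears on the present change only loosely, showing that a small group exchange on that aromatic carbon moved the partition coefficient little. The step from compound 2 to compound 3 is therefore an estimate, expected as a number 0.52 log units lower from compound 2 to compound 3 (beyond the scatter), a modest decrease. Compound 3 is expected to give 3.8 in this assay, with a range from 3.4 to 4.3.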

Compound 3, partition coefficient: 4.01
Beside the measured number, compound 3's estimate is 0.21 log units below it, and the stated range covers the measured number.
By their numbers in this assay, from the lowest: compound 3; then compounds 2 and 1 (each within the scatter of the next).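

In this assay, the aromatic carbon para to a large group now shows a change that clears the scatter: the earlier step only exchanged one small group for another, whereas hydrogen in place of methyl gives (a number 0.31 log units lower from compound 2 to compound 3 (beyond the scatter)) and hydrogen in place of chloro gives (a number 0.59 log units lower from compound 1 to compound 3 (beyond the scatter)). Compound 3, with no substituent on that carbon, therefore stands lowest of the three, with both of its steps beyond the scatter, while methyl and chloro still cannot be told apart from each other, so at this position the measurable difference so far lies between having a small group and having none. No measurement is at hand that would explain the size of these steps or tie them to any property of the groups.

The compounds shown leave open how an amine, a methoxy group or a carboxylic acid on that same carbon would read in this assay, as only hydrogen, methyl and chloro appear there. They also leave open whether hydrogen in place of methyl would give a similar step at any other position or on a different core.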